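Switching the pyrazole attachment point on the shared core

This account rests on a few compounds, and the source may have more. Where it says the series, first, only, none or still open, it means among the compounds named here.

Measured compounds:
compound 1 `Cc1n[nH]cc1-c1cccc2c1CCC2c1ncc[nH]1`, 91%
compound 2 `c1ccc(-c2cccc3c2CCC3c2ncc[nH]2)nc1`, 53%
compound 3 `Cn1ccc(-c2cccc3c2CCC3c2ncc[nH]2)n1`, 19%

In a functional assay on CHO cells for agonist activity at Alpha-1A adrenergic receptor (Homo sapiens), read by FLIPR and calcium flux (on this read-out higher numbers stand for larger maximal responses and lower numbers for smaller maximal responses), compound 3 gives the lowest of the three numbers, with a number 34 percentage points lower from compound 2 to compound 3 (beyond the scatter) and a number 72 percentage points lower from compound 1 to compound 3 (beyond the scatter). Compound 4 `Cn1nccc1-c1cccc2c1CCC2c1ncc[nH]1` differs from compound 3 in one place: 1-methyl-1H-pyrazol-5-yl in place of 1-methyl-1H-pyrazol-3-yl on an aromatic carbon. Among the compounds with values here, no measured step exchanges one methylpyrazole isomer for another, so the bearing steps are indirect; each replacement of the aromatic group so far moved the maximal response by a large amount, including a number 38 percentage points lower from compound 1 to compound 2 (beyond the scatter). Since compound 3 sits at the bottom, room lies mainly upward, and a step of a number 21 percentage points higher from compound 3 to compound 4 (beyond the scatter) is expected, though with wide uncertainty. Compound 4 is therefore estimated at 40%, within 10% to 80%.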

Compound 4, largest response reached (Emax), in percent of the reference or control that the assay uses: 58%
Estimate against measurement, compound 4: 18 percentage points below; measured number inside the range.
By their numbers in this assay, from the lowest: compound 3; then compounds 2 and 4 (each within the scatter of the next); then compound 1.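

In this assay the two methylpyrazoles have the same atoms joined differently, yet the 1-methyl-1H-pyrazol-5-yl group in place of 1-methyl-1H-pyrazol-3-yl gives a number 39 percentage points higher from compound 3 to compound 4 (beyond the scatter) as its step, so the attachment of the ring alone can shift the maximal response at this position. The same group in place of pyridin-2-yl gives a number 5 percentage points higher from compound 2 to compound 4 (within the scatter) while in place of 3-methyl-1H-pyrazol-4-yl it gives a number 33 percentage points lower from compound 1 to compound 4 (beyond the scatter) as its step. Nothing at hand explains these differences. Still open, going by these compounds, is how a phenyl group or a 1-methyl-1H-pyrazol-4-yl group would behave at this position.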